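Notes on the oxygen-linked side chain of the shared core

The source may report more compounds than this note shows. Statements on the series, on what has been measured and on what is new or still open speak of the compounds shown alone.

Measured in a functional assay on HEK293 cells for agonist activity at G-protein coupled receptor 39 (Homo sapiens), read by scintillation proximity assay and inositol phosphate accumulation, with a stated time of 75 min; on this read-out lower numbers stand for an effect already at smaller amounts and higher numbers for an effect only at larger amounts of compound:
- compound 1 `Cc1nn(-c2ncnc3nc[nH]c23)c2c1C(OCC(=O)c1ccc(F)cc1)CC(=O)N2`: 973 nM
- compound 2 `Cc1nn(-c2ncnc3nc[nH]c23)c2c1C(OCCc1ccccc1)CC(=O)N2`: 40 nM
- compound 3 `Cc1nn(-c2ncnc3nc[nH]c23)c2c1C(OCc1ccccc1C#N)CC(=O)N2`: 127 nM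

Compound 1 gives the highest number of the three. The steps away from it are a 24-fold lower number from compound 1 to compound 2 (1.39 log units; beyond the scatter) and a 7.7-fold lower number from compound 1 to compound 3 (0.88 log units; beyond the scatter), both beyond the scatter; between the two smaller side chains the step is a 3.2-fold higher number from compound 2 to compound 3 (0.50 log units; beyond the scatter).

Compound 4 `Cc1nn(-c2ncnc3nc[nH]c23)c2c1C(OCC(C)C)CC(=O)N2` takes the change (isopropyl in place of (4-fluorophenyl)carbonyl on a saturated chain carbon bound to an oxygen on a saturated carbon). Among the compounds with values here, both measured steps from compound 1 replace the (4-fluorophenyl)carbonyl and lower the number, so a drop in this assay is expected for compound 4 as well, though isopropyl brings no ring as benzyl and 2-cyanophenyl do, and no measured compound shows such a chain. A step of about a 3.2-fold lower number from compound 1 to compound 4 (0.51 log units; beyond the scatter) is therefore expected. Compound 4 is estimated at 300 nM, within 80 nM to 1200 nM.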

Compound 4, half-maximal effective concentration: 111 nM
Compound 4: the middle estimate sits 2.7-fold (0.43 log units) above what was measured, within the range that was stated.
By their numbers in this assay, from the lowest: compound 2; then compounds 4 and 3 (each within the scatter of the next); then compound 1.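

A ring on this side chain is not needed for a low number: isopropyl in place of (4-fluorophenyl)carbonyl gives an 8.8-fold lower number from compound 1 to compound 4 (0.94 log units; beyond the scatter), and isopropyl in place of 2-cyanophenyl gives a 1.1-fold lower number from compound 3 to compound 4 (0.06 log units; within the scatter), leaving those two groups indistinguishable here. Benzyl keeps an edge over isopropyl, with a 2.8-fold higher number from compound 2 to compound 4 (0.44 log units; beyond the scatter). No evidence bears on the reason for these steps.

Still open, going by these compounds, is how an amine, a carboxylic acid or a longer chain would read at this place. Also open, on these data alone, is whether cyclohexyl in place of benzyl would hold the number of compound 2.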